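From Cyclohexylmethyl Amide to Pyrrolidine Amide

The source may report more compounds than this note shows. Statements on the series, on what has been measured and on what is new or still open speak of the compounds shown alone.

Going by the values given here, compound 2 `O=C(NCC1CCCCC1)c1cccc(N2C(=O)N/C(=C\c3ccc(O)cc3)C2=O)c1` is the only compound of the pair with a number in a functional assay on NCI-H292 cells (Homo sapiens) for antiproliferative activity; a higher number here means a weaker inhibitor, a lower number a stronger inhibitor: compound 2 gives 17900 nM. Compound 1 `Cc1cccc(N2C(=O)N/C(=C\c3ccc(O)cc3)C2=O)c1`, which carries a methyl in place of the carboxamide, returns only a limit; in this assay compound 1 gives > 200000 nM, which is the limit of > 200000 nM in this assay, at which 1 of the 2 values shown sits. Among the compounds with values here, the single measured step, an at least 11-fold lower number from compound 1 to compound 2 (1.04 log units; beyond the scatter), thus shows a large gain attached to the (cyclohexylmethyl)carbamoyl group. Compound 3 `O=C(c1cccc(N2C(=O)N/C(=C\c3ccc(O)cc3)C2=O)c1)N1CCCC1` keeps the carboxamide but alters its amine part: pyrrolidin-1-yl in place of (cyclohexylmethyl)amino on a carbonyl carbon. Within the data shown here, no measured step covers this exchange; the step from compound 1 to compound 2 only shows that the carboxamide matters, not how its amine part may be varied. A moderately higher number than compound 2 is expected, so that a 2.2-fold higher number from compound 2 to compound 3 (0.35 log units; beyond the scatter) is the estimated step. For compound 3 the estimate in this assay is 40000 nM, within 12000 nM to 150000 nM.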

Compound 3, half-maximal inhibitory concentration: > 200000 nM
Compound 3: a limit, no number; the forecaster's own chance of this, stated with the estimate: 15%; middle value at least 5.0-fold (0.69 log units) from the limit.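

On the carbonyl carbon, pyrrolidin-1-yl in place of (cyclohexylmethyl)amino gives an at least 11-fold higher number from compound 2 to compound 3 (1.04 log units; beyond the scatter) in this assay and so removes the measurable activity of compound 2. The carboxamide alone is therefore not enough, and the amine part on it decides whether a number can be read at all. The value of compound 3 is a limit, not a number, and its step to compound 1, whose value is also a limit, cannot be read: the limit of > 200000 nM in this assay, at which 2 of the 3 values shown sit.

The exchange removes the six-membered ring of carbon and the hydrogen-bond donor together, and the compounds shown do not separate these two differences. On these data alone, it also remains open how an amide of benzylamine or of piperidine would behave in this assay.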